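The source may report more compounds than this note shows. Statements on the series, on what has been measured and on what is new or still open speak of the compounds shown alone.

In a functional assay with Oryctolagus cuniculus as the target (on this read-out higher numbers stand for weaker inhibition and lower numbers for stronger inhibition), compound 1 (`COc1ccc(-c2nc(N=C(N)N)sc2-c2ccc(OC)cc2)cc1`) gives 31000 nM as a measured number. Compound 2 (`COc1ccc(-c2nc(/N=C(\N)NC3CCCCC3)sc2-c2ccc(OC)cc2)cc1`) gives > 1000 nM, which is a limit of the assay and not a number. Compound 3 (`COc1ccc(-c2nc(/N=C(\N)[N+]3(C)CCCCC3)sc2-c2ccc(OC)cc2)cc1`) gives > 1000 nM, which is likewise a limit. Compound 3 therefore has no number of its own and stands at the limit of > 1000 nM in this assay, at which 2 of the 3 values shown sit.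

Compound 4 (`COc1ccc(-c2nc(/N=C(\N)n3ccnc3)sc2-c2ccc(OC)cc2)cc1`) differs from compound 3 by one change: a group of 5 heavy atoms (3 carbon, 2 nitrogen; one five-membered aromatic ring with 2 hetero atoms) in place of a group of 7 heavy atoms (6 carbon, 1 nitrogen; one six-membered non-aromatic ring with 1 hetero atom), on a carbon with a double bond to nitrogen. The 1H-imidazol-1-yl group, with no net charge, enters on a carbon with a double bond to nitrogen, and the group with net charge +1 leaves.

For the measured compounds named here, three measured steps bear on this place: a step that the limit leaves unreadable from compound 1 to compound 2, a step that the limit leaves unreadable from compound 1 to compound 3 and a step that the two limits leave unreadable from compound 2 to compound 3. None has a readable size, so they predict no direction in this assay. Going by the values given here, the expectation leans instead on compound 1 at 31000 nM, the only number available. The expected change is a step that the limit leaves unreadable from compound 3 to compound 4, with no direction that can be called in advance. The estimate for compound 4 is 8000 nM, within an expected range from 1200 nM to 50000 nM.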

Compound 4, half-maximal inhibitory concentration: > 100 nM
Compound 4: only a limit was reported (the forecaster's own chance of this, stated with the estimate: 55%); the middle value lies beyond the limit too.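

In this assay, compound 4 gives only a limit, so its steps from compound 1, compound 2 and compound 3 cannot be read. The compounds shown leave open how compound 2, compound 3 and compound 4 rank against one another and against compound 1.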